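This account rests on a few compounds, and the source may have more. Where it says the series, first, only, none or still open, it means among the compounds named here.

Compound 1 `CC1(C)[C@H]2CC[C@]1(C)N(Cc1cn(-c3cccc(Cl)c3)nn1)C(=O)C2` gives 510 nM in a functional assay on SGC-7901 cells (Homo sapiens) for inhibition, read by MTT assay, with a stated time of 24 h; on this read-out higher numbers stand for weaker inhibition and lower numbers for stronger inhibition.
Compound 2 `CC1(C)[C@H]2CC[C@]1(C)N(Cc1cn(-c3cccc(O)c3)nn1)C(=O)C2` gives 270 nM in this assay.
Compound 3 `CC1(C)[C@H]2CC[C@]1(C)N(Cc1cn(-c3cccc(F)c3)nn1)C(=O)C2` gives 530 nM in this assay.

Compound 3 carries the highest number of the three in this assay, yet none of its companions stands apart from it: compound 1 sits closest, with a 1.0-fold higher number from compound 1 to compound 3 (0.02 log units; within the scatter), and compound 2 furthest, with a 2.0-fold higher number from compound 2 to compound 3 (0.29 log units; within the scatter). The unmeasured compound 4 `CC1(C)[C@H]2CC[C@]1(C)N(Cc1cn(-c3ccc(O)cc3)nn1)C(=O)C2` is reached from compound 3 by a single change: 4-hydroxyphenyl in place of 3-fluorophenyl on an aromatic nitrogen.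

Going by the values given here, two measured steps bear on this change, both touching the same aromatic substituent. Exchanging chloro for hydroxy gave a 1.9-fold lower number from compound 1 to compound 2 (0.28 log units; within the scatter), and exchanging hydroxy for fluoro gave a 2.0-fold higher number from compound 2 to compound 3 (0.29 log units; within the scatter). Among the compounds with values here, both stay inside the scatter, and neither addresses a hydroxy group moved to a different position on the ring, so no measured pair speaks to that part of the change. Taking compound 2 as the nearest guide, a modest drop in the number is expected for compound 4, of about a 1.8-fold lower number from compound 3 to compound 4 (0.25 log units; within the scatter), a step that does not exceed the scatter. Compound 4 is therefore estimated at 300 nM in this assay, within a range from 120 nM to 800 nM.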

Compound 4, half-maximal inhibitory concentration: 330 nM
Compound 4: the middle estimate sits 1.1-fold (0.04 log units) below what was measured, within the range that was stated.
By their numbers in this assay, from the lowest: compounds 2, 4, 1 and 3 (each within the scatter of the next).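

Moving the hydroxy group on the ring, which no earlier pair addressed, gives a 1.2-fold higher number from compound 2 to compound 4 (0.09 log units; within the scatter) in this assay, so 3-hydroxyphenyl and 4-hydroxyphenyl on the aromatic nitrogen cannot be told apart on this read-out. Going by these compounds alone, the exchanges that alter both the substituent and its place on the ring, a 1.6-fold lower number from compound 3 to compound 4 (0.21 log units; within the scatter) and a 1.5-fold lower number from compound 1 to compound 4 (0.19 log units; within the scatter), also stay inside the scatter, so all four aryl groups seen at this position now lie within the scatter of one another, with no compound going against this. No measurement of any other property accompanies these compounds, so the data offer no explanation for these numbers.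

The compounds shown contain only one pair in which a group changes place on the ring, so it remains open whether moving the fluoro or chloro group would behave as moving the hydroxy group does. As far as these compounds go, it also remains open whether an amine, a carboxylic acid, a longer chain or an unsubstituted phenyl ring at this position would give a step beyond the scatter.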